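Phenyl versus pyridyl core: methoxy-to-hydroxy step compared

The source may hold more compounds than are shown below. What is called first, only, known or untested is meant among the compounds shown, and "the series" means these compounds.

Measured compounds and their values in a functional assay on HCC827 cells (Homo sapiens) for inhibition, read by fluorescence and resazurin assay, with a stated time of 72 h; on this read-out higher numbers stand for weaker inhibition of growth and lower numbers for stronger inhibition of growth:

compound 1 `COc1ccccc1-c1ccc(Nc2nc(N[C@H]3CC[C@H](N)CC3)nc3c2ncn3C2CCCC2)cc1` gives 2300 nM
compound 2 `N[C@H]1CC[C@H](Nc2nc(Nc3ccc(-c4ccccc4O)cc3)c3ncn(C4CCCC4)c3n2)CC1` gives 2530 nM
compound 3 `COc1ccccc1-c1ccc(Nc2nc(N[C@H]3CC[C@H](N)CC3)nc3c2ncn3C2CCCC2)cn1` gives 638 nM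

Compound 1 and compound 2 share a core and differ only by the change (hydrogen in place of methyl on an oxygen on an aromatic ring). In this assay the step of a 1.1-fold higher number from compound 1 to compound 2 (0.04 log units; within the scatter) is small, so these two values are read as the same within the usual scatter.

Compound 3 carries a different core; how it differs from compound 1 is not broken down here. In this assay compound 3 stands lowest of the three numbers, and its gaps to compound 1 and to compound 2 both lie beyond the scatter.

Compound 4 `N[C@H]1CC[C@H](Nc2nc(Nc3ccc(-c4ccccc4O)nc3)c3ncn(C4CCCC4)c3n2)CC1` is not yet measured. It differs from compound 3 by hydrogen in place of methyl on an oxygen on an aromatic ring, which is the same change as from compound 1 to compound 2, made at the same place, on the core of compound 3 rather than on that of compound 1. Among the measured compounds shown here, with only one earlier instance of this change on hand, the expectation for compound 4 rests on that single step: it is expected that the step of a 1.1-fold higher number from compound 3 to compound 4 (0.04 log units; within the scatter) will be as small as the earlier one, because the step of a 1.1-fold higher number from compound 1 to compound 2 (0.04 log units; within the scatter) stayed within the scatter. On that basis compound 4 is estimated at 700 nM in this assay, with a range from 300 nM to 1600 nM expected to hold most repeat measurements.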

Compound 4, concentration for 50% growth inhibition: 653 nM
Beside the measured number, compound 4's estimate is 1.1-fold (0.03 log units) above it; low and high end bracket the measured number.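

In this assay, the methoxy to hydroxy change on the core of compound 3 gives a 1.0-fold higher number from compound 3 to compound 4 (0.01 log units; within the scatter), so the two values of this pair are read as the same. Set beside the first instance of the change, the step on the second core shows no difference that can be told from the scatter: the same change on two cores in this assay, a 1.1-fold higher number (0.04 log units; within the scatter) from compound 1 to compound 2 and a 1.0-fold higher number (0.01 log units; within the scatter) from compound 3 to compound 4, 1.1-fold (0.03 log units) apart, within the scatter of two such steps This supports a narrow reading, namely that on these two cores 2-methoxyphenyl and 2-hydroxyphenyl cannot be told apart in this read-out, but with only two pairs in a single cell assay it does not show that the same would hold on any further core or in another assay, and it gives no explanation of the result.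

The compounds shown leave open whether a group other than methyl or hydrogen on that oxygen, such as an ethyl group or a longer chain, would also give values that cannot be told apart on both cores. They also leave open whether replacing the whole hydroxy group with an amine or a carboxylic acid would keep the two cores in step in this assay.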